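Swapping a Pyrazole for a Dimethylisoxazole on the Core

The source may hold more compounds than are shown below. What is called first, only, known or untested is meant among the compounds shown, and "the series" means these compounds.

The three compounds measured so far, all sharing one core:

compound 1 `Cc1cc(C)c(CN2CCc3c(F)cc(O[C@@H]4CCOC4)c(Cl)c3C2=O)c(=O)[nH]1` gives 1030 nM
compound 2 `Cc1cc(C)c(CN2CCc3c(Cl)cc(-c4cn[nH]c4)c(Cl)c3C2=O)c(=O)[nH]1` gives 1580 nM
compound 3 `Cc1cc(C)c(CN2CCc3ccc(OC(C)C)c(Cl)c3C2=O)c(=O)[nH]1` gives 1160 nM

All three were tested in a functional assay on KARPAS-422 cells (Homo sapiens) for inhibition, with a stated time of 72 h; on this read-out higher numbers stand for weaker inhibition and lower numbers for stronger inhibition. Compound 2 shows the highest of the three numbers, yet its gap to compound 3 and its gap to compound 1 both sit inside the usual scatter of repeated measurements of this kind, so none of the three can be called stronger or weaker than another on these data.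

Compound 4 `Cc1cc(C)c(CN2CCc3c(Cl)cc(-c4c(C)noc4C)c(Cl)c3C2=O)c(=O)[nH]1` has not yet been measured. It differs from compound 2 in one place: 3,5-dimethyl-1,2-oxazol-4-yl in place of 1H-pyrazol-4-yl on an aromatic carbon. The group that leaves carries a hydrogen-bond donor; the one that enters carries none and brings two methyl groups on the five-membered ring instead.

For the measured compounds named here, no pair of measured compounds shows a change of this kind, so there is nothing to copy from. With no such guide, the expectation for compound 4 rests on compound 2 alone, and the step of a 1.1-fold lower number from compound 2 to compound 4 (0.02 log units; within the scatter) is expected to stay within the scatter, with no clear direction. Compound 4 is therefore estimated to give 1500 nM, with a likely range from 600 nM to 4000 nM.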

Compound 4, half-maximal inhibitory concentration: 25 nM
For compound 4 the middle estimate is 60-fold (1.78 log units) above the measured one; the whole stated range lies above it.
By their numbers in this assay, from the lowest: compound 4; then compounds 1, 3 and 2 (each within the scatter of the next).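

In this assay the change of 1H-pyrazol-4-yl to 3,5-dimethyl-1,2-oxazol-4-yl on this aromatic carbon gives a 63-fold lower number from compound 2 to compound 4 (1.80 log units; beyond the scatter) and so separates compound 4 clearly from the other compounds, whose numbers all lie within the scatter of their neighbours. For the compounds shown here, this is the first single-place change available here, and it shows that the five-membered ring at this position can have a very large effect on the read-out in these cells. Several things change together in this one step, since the entering group has no hydrogen-bond donor, has one more hydrogen-bond acceptor and carries two methyl groups, and nothing presented here explains the size of the step or shows which of these differences matters.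

The compounds shown leave open whether the two methyl groups or the change of ring is what counts, a question that 3,5-dimethyl-1H-pyrazol-4-yl and the unsubstituted 1,2-oxazol-4-yl could each help to settle. They also leave open how far the position tolerates other groups, such as a phenyl ring or a 3,5-dimethyl-1,2-oxazol-4-yl with one methyl replaced by ethyl.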